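A few compounds are considered here, and "the series" means these few. Any claim that something is new, unique, unknown or untested is made for them only; others in the source may bear on it.

Of the compounds shown here, three share one core and have been tested in a functional assay on DU-145 cells (Homo sapiens) for cytotoxicity, read by CCK-8 assay; a higher number here means a weaker inhibitor, a lower number a stronger inhibitor. Compound 1 `Oc1cccc(-c2cc(-c3ccsc3)cc(-c3ccccc3O)n2)c1` carries a thiophen-3-yl group; in this assay compound 1 reaches only the assay limit of > 50000 nM, so no number is known for it. Compound 2 `Oc1cccc(-c2cc(-c3ccco3)cc(-c3ccccc3O)n2)c1` carries a furan-2-yl group instead, and in this assay compound 2 gives 1790 nM. Compound 3 `Oc1cccc(-c2cc(-c3ccco3)cc(-c3cccc(O)c3)n2)c1` keeps the furan-2-yl group but has a 3-hydroxyphenyl group in place of a 2-hydroxyphenyl group; in this assay compound 3 gives 2150 nM. Compound 2 stands at the smaller of the two numbers shown, yet its gap to compound 3 is within the usual scatter, so neither can be called the stronger.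

The measured steps are an at least 27-fold lower number from compound 1 to compound 2 (1.44 log units; beyond the scatter) and a 1.2-fold higher number from compound 2 to compound 3 (0.08 log units; within the scatter). Compound 4 `Oc1cccc(-c2cc(-c3ccoc3)cc(-c3ccccc3O)n2)c1` differs from compound 2 in one place: furan-3-yl in place of furan-2-yl on an aromatic carbon. The large step from compound 1 to compound 2 shows that the five-membered ring can move the number strongly, but that step altered both the hetero atom and the point at which the ring is joined, whereas the change to compound 4 alters only the latter. Among the measured compounds shown here, no measured step isolates that change. The expected step of a 2.2-fold higher number from compound 2 to compound 4 (0.35 log units; beyond the scatter) is therefore a modest weakening with wide uncertainty. Compound 4 is estimated at 4000 nM, with a range from 1200 nM to 20000 nM.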

Compound 4, half-maximal inhibitory concentration: 2790 nM
For compound 4 the middle estimate is 1.4-fold (0.16 log units) above the measured one, and the stated range covers the measured number.
By their numbers in this assay, from the lowest: compounds 2, 3 and 4 (each within the scatter of the next). At a limit, above all of these: compound 1.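

In this assay, changing only the point at which the furan ring is joined to the shared core gives a 1.6-fold higher number from compound 2 to compound 4 (0.19 log units; within the scatter), so this change at the position opposite the ring nitrogen has no effect that can be told apart from the scatter. With the joining point held the same, furan-3-yl in place of thiophen-3-yl gives an at least 17-fold lower number from compound 1 to compound 4 (1.25 log units; beyond the scatter), so among these compounds the large change goes with the swap of the ring's sulfur for oxygen, which the earlier step from thiophen-3-yl to furan-2-yl could not separate from the shift in joining point. The size of this step is only a bound, because compound 1 stands at a limit and has no exact number: the limit of > 50000 nM in this assay, at which 1 of the 4 values shown sits.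

At this position the compounds shown carry only thiophen-3-yl and the two furan rings, so it stays open whether thiophen-2-yl would behave like compound 1 or like the furan compounds. Going by these compounds, it also stays open what a plain phenyl ring, an amine or a carboxylic acid would do at the same place.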